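Fluoro position on the benzylamine arm of a quinoline series

This account rests on a few compounds, and the source may have more. Where it says the series, first, only, none or still open, it means among the compounds named here.

Measured so far:
compound 1, `COc1ccc2nc(C)cc(NCc3cccc(F)c3)c2c1`, 11300 nM
compound 2, `COc1ccc2nc(C)cc(NCc3ccccc3F)c2c1`, 14000 nM
compound 3, `COc1ccc2nc(C)cc(NCc3cc(F)cc(F)c3)c2c1`, 13300 nM

All three numbers come from a functional assay on MCF-10A cells (Homo sapiens) for antiproliferative activity, with a stated time of 48 h (a higher number here means that more compound is needed for the effect, a lower number that less compound is needed), and sit within the scatter of one another: a 1.2-fold higher number from compound 1 to compound 2 (0.09 log units; within the scatter) and a 1.2-fold higher number from compound 1 to compound 3 (0.07 log units; within the scatter). Compound 2 differs from compound 1 by 2-fluorophenyl in place of 3-fluorophenyl on a saturated chain carbon bound to a nitrogen on an aromatic ring. Compound 3 arises from compound 1 by fluoro in place of hydrogen on an aromatic carbon. Compound 4, `COc1ccc2nc(C)cc(NCc3c(F)cccc3F)c2c1`, not yet measured, arises from compound 2 by fluoro in place of hydrogen on an aromatic carbon, the same kind of change, though here the place is ortho to a large group rather than meta to it. Since the step from compound 1 to compound 3 stayed within the scatter, the step from compound 2 to compound 4 in this assay is expected to be of similar size, about a 1.1-fold higher number from compound 2 to compound 4 (0.03 log units; within the scatter). Compound 4 is therefore estimated at 15000 nM, between 7000 nM and 35000 nM.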

Compound 4, half-maximal effective concentration: 13600 nM
Compound 4: middle estimate off by 1.1-fold (0.04 log units), on the high side, and the stated range covers the measured number.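

Fluoro in place of hydrogen on an aromatic carbon of compound 2 gives a 1.0-fold lower number from compound 2 to compound 4 (0.01 log units; within the scatter). In this assay the change reads the same on both cores, with no difference between its two steps beyond the scatter: the same change on two cores in this assay, a 1.2-fold higher number (0.07 log units; within the scatter) from compound 1 to compound 3 and a 1.0-fold lower number (0.01 log units; within the scatter) from compound 2 to compound 4, 1.2-fold (0.08 log units) apart, within the scatter of two such steps. For the compounds shown here, this shows only that the change leaves the number within the scatter in these two pairs; with neither step beyond the scatter, it does not show that a measurable effect carries from one core to another.

Still open, on these data alone, is whether a trifluoromethyl or methoxy group on the same aromatic ring would give a step beyond the scatter. The same question applies to a longer chain in place of the benzyl carbon.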